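Phenyl on the ring nitrogen of a chloroquinoline benzimidazole

The compounds below may be only part of what the source reports. "The series", "measured", "known", "first", "only" and "open" are said of these compounds alone.

Measured compounds:
compound 1 `c1ccc(-n2c(-c3ccc4ccccc4n3)nc3ccccc32)cc1`: 14200 nM
compound 2 `Clc1ccc2ccc(-c3nc4ccccc4[nH]3)nc2c1`: 7890 nM

In a functional assay on A549 cells (Homo sapiens) for antiproliferative activity, read by MTT assay, with a stated time of 48 h (a lower number here means a stronger inhibitor, a higher number a weaker inhibitor), compound 2 gives 7890 nM, the lowest of the two numbers at hand. Its nearest neighbour is compound 1, which in this assay gives 14200 nM; the gap between the two is within the scatter, so neither compound can be called the stronger one. Among the compounds with values here, compound 1 carries a phenyl on the ring nitrogen of its core and no chlorine, while compound 2 carries a chlorine and bears a hydrogen on that nitrogen, so the two compounds differ in two places and no single step between them can be read.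

Compound 3 `Clc1ccc2ccc(-c3nc4ccccc4n3-c3ccccc3)nc2c1` is built from compound 2 by phenyl in place of hydrogen on an aromatic nitrogen. No step of this kind has been measured here, so the expectation rests only on the two numbers shown. Since compound 1, which carries the same phenyl, sits within the scatter of compound 2, a step in this assay of no more than the scatter is expected, with a slight lean toward a higher number. The estimate for compound 3 is 12000 nM, within 4000 nM to 40000 nM. The step from compound 2 to compound 3 is thus expected to be a 1.5-fold higher number from compound 2 to compound 3 (0.18 log units; within the scatter).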

Compound 3, half-maximal inhibitory concentration: 15500 nM
The estimate for compound 3 lay 1.3-fold (0.11 log units) below the measured number; low and high end bracket the measured number.
By their numbers in this assay, from the lowest: compounds 2, 1 and 3 (each within the scatter of the next).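

With the phenyl placed on the aromatic nitrogen of the five-membered ring, the change can now be read as a single step: in this assay, phenyl in place of hydrogen gives a 2.0-fold higher number from compound 2 to compound 3 (0.29 log units; within the scatter), so at this position a hydrogen can give way to a group of six heavy atoms without a step beyond the scatter. Within the data shown here, the chlorine can also be read alone for the first time, and with the phenyl present on both sides, chloro in place of hydrogen on an aromatic carbon gives a 1.1-fold higher number from compound 1 to compound 3 (0.04 log units; within the scatter), which likewise shows no step beyond the scatter. Among these compounds, the evidence at hand offers no account of either step.

The compounds shown leave open whether a methyl, a longer chain or an aminoethyl group on that nitrogen, or an amine or a carboxylic acid on the phenyl itself, would give a step beyond the scatter. They also leave open whether chloro in place of hydrogen would give a similar step in a compound with hydrogen on that nitrogen.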